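This account rests on a few compounds, and the source may have more. Where it says the series, first, only, none or still open, it means among the compounds named here.

Working notes on the series.

Compound 1 `C[C@H](NC(=O)c1cccc(-c2ccc(NS(C)(=O)=O)nc2)c1)C(=O)Nc1ccc(Cl)c(C(F)(F)F)c1` in a functional assay on K562 cells (Homo sapiens) for inhibition, read by MTT assay, with a stated time of 48 h (a higher number here means a weaker inhibitor, a lower number a stronger inhibitor), gives 4660 nM. Compound 2 `CC(=O)Nc1ccc(-c2cccc(C(=O)N[C@@H](C)C(=O)Nc3ccc(Cl)c(C(F)(F)F)c3)c2)cn1` in this assay gives 42800 nM; the change is acetyl in place of methylsulfonyl on a nitrogen on an aromatic ring, and the step is a 9.2-fold higher number from compound 1 to compound 2 (0.96 log units; beyond the scatter). Compound 3 `C[C@H](NC(=O)c1ccc(-c2ccc(NS(C)(=O)=O)nc2)cc1)C(=O)Nc1ccc(Cl)c(C(F)(F)F)c1` carries the same atoms as compound 1 joined differently; the difference between the two cores is not broken down here. In this assay compound 3 gives 7240 nM, within the scatter of compound 1, so no order between them is claimed.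

Compound 4 `CC(=O)Nc1ccc(-c2ccc(C(=O)N[C@@H](C)C(=O)Nc3ccc(Cl)c(C(F)(F)F)c3)cc2)cn1` is the unmeasured partner of compound 3. The change is acetyl in place of methylsulfonyl on a nitrogen on an aromatic ring, the same kind of change as from compound 1 to compound 2, and the two place descriptions read alike word for word. Within the data shown here, since the only measured instance of this change is the step from compound 1 to compound 2, and compounds 1 and 3 sit within the scatter of each other in this assay, a step of comparable size is expected from compound 3, estimated as a 6.9-fold higher number from compound 3 to compound 4 (0.84 log units; beyond the scatter). Compound 4 is accordingly expected to give about 50000 nM in this assay, within roughly 18000 nM to 140000 nM.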

Compound 4, half-maximal inhibitory concentration: 107000 nM
Compound 4: middle estimate off by 2.1-fold (0.33 log units), on the low side, within the range that was stated.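

Acetyl in place of methylsulfonyl on the nitrogen gives a weaker inhibitor on the second core as well: in this assay the new step is a 15-fold higher number from compound 3 to compound 4 (1.17 log units; beyond the scatter). Set beside the earlier step, the two run the same way and their sizes cannot be told apart: the same change on two cores in this assay, a 9.2-fold higher number (0.96 log units; beyond the scatter) from compound 1 to compound 2 and a 15-fold higher number (1.17 log units; beyond the scatter) from compound 3 to compound 4, 1.6-fold (0.21 log units) apart, within the scatter of two such steps. The change therefore carries over between the core of compound 1 and the core of compound 3, but these two cores hold the same atoms joined differently, so this does not show that it would carry to a more distant core, and it gives no reason for the loss.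

The compounds shown cover only methylsulfonyl and acetyl on this nitrogen, so it stays open how a free amine, a urea or a longer chain such as ethylsulfonyl would compare. Also open, as far as these compounds go, is whether the step keeps its size when the rest of the shared structure changes, for instance with a carboxylic acid in place of the trifluoromethyl group.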